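A few compounds are considered here, and "the series" means these few. Any claim that something is new, unique, unknown or untested is made for them only; others in the source may bear on it.

Measured compounds:

- compound 1, `Cc1ccc(Nc2ccnc(NCCNc3ccnc4cc(Cl)ccc34)n2)cc1`, in an ADME assay on Vero cells (Chlorocebus sabaeus) for cytotoxicity, read by neutral red uptake, with a stated time of 72 h; a higher number here means a weaker inhibitor, a lower number a stronger inhibitor: 13600 nM
- compound 2, `COc1ccc(Nc2ccnc(NCCNc3ccnc4cc(Cl)ccc34)n2)cc1`, this assay: "not active" (no number reported)
- compound 3, `Fc1ccc(Nc2ccnc(NCCCCNc3ccnc4cc(Cl)ccc34)n2)cc1`, this assay: "not active" (no number reported)

Compound 3 stands without a single number in this assay; the entry for it reads "not active" (no number reported), and compound 2 stands in the same way, with no number reported either. Only compound 1 carries a numerical read-out, 13600 nM. For the measured compounds named here, no step between measured compounds is available, so nothing can be said about how the size of the aryl-amino substituent or the length of the linking chain moves the read-out beyond what the three entries show on their own.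

The unmeasured compound 4, `COc1cc(Nc2ccnc(NCCCCNc3ccnc4cc(Cl)ccc34)n2)cc(OC)c1`, differs from compound 3 in one place: 3,5-dimethoxyphenyl in place of 4-fluorophenyl on a nitrogen on an aromatic ring. The linking chain and the rest of the shared core are kept.

Going by the values given here, with no step to lean on and two of three measured compounds reporting no number, no direction can be assigned to this change; any shift in this assay from compound 3 to compound 4 is expected to stay within the usual scatter, and it is judged more likely than not that compound 4 will again return no number. Where a number is obtained, compound 4 is estimated at 20000 nM, with a range of 8000 nM to 60000 nM.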

Compound 4, half-maximal inhibitory concentration: 12500 nM
For compound 4 the middle estimate is 1.6-fold (0.20 log units) above the measured one; low and high end bracket the measured number.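

No new step can be read in this assay here: compound 4 at 12500 nM cannot be set against compound 3, which reports no number. No measured evidence bears on this result. Still open, as far as these compounds go, is how replacing 4-fluorophenyl with 3,5-dimethoxyphenyl on the shared core moves the read-out.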